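A few compounds are considered here, and "the series" means these few. Any claim that something is new, unique, unknown or untested is made for them only; others in the source may bear on it.

Among the measured compounds shown here, compound 1 `COc1ccc(NC2=CC(=O)c3c(nc4n3[C@H]3OC[C@@H](O)[C@H]3OC4)C2=O)cc1` is the only compound here with a numbered result: in a functional assay on ECa-109 cells for inhibition, with ECa-109 cell line (Homo sapiens) as the target, read by sulforhodamine B assay (on this read-out higher numbers stand for weaker inhibition and lower numbers for stronger inhibition), compound 1 gives 3410 nM. Two related compounds reach only the limit of the assay. Compound 2 `CCCc1ccc(NC2=CC(=O)c3nc4n(c3C2=O)[C@H]2OC[C@@H](O)[C@H]2OC4)cc1` gives in this assay a limit, > 4000 nM. Compound 3 `COc1ccc(NC2=CC(=O)c3nc4n(c3C2=O)[C@H]2OC[C@@H](O)[C@H]2OC4)cc1` likewise gives in this assay a limit, > 4000 nM. The step that the two limits leave unreadable from compound 2 to compound 3 cannot be sized, since both values sit at the limit of > 4000 nM in this assay, at which 2 of the 3 values shown sit. Compound 4 `CCc1ccc(NC2=CC(=O)c3c(nc4n3[C@H]3OC[C@@H](O)[C@H]3OC4)C2=O)cc1` differs from compound 1 by ethyl in place of methoxy on an aromatic carbon. For the measured compounds named here, no measured step bears directly on this change, and the pair of limits gives no usable size. The expected step of a 1.2-fold higher number from compound 1 to compound 4 (0.07 log units; within the scatter) is therefore none beyond the scatter. A limit instead of a number is also quite possible for compound 4. Compound 4 is estimated at 4000 nM, ranging from 1800 nM to 9000 nM.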

Compound 4, half-maximal inhibitory concentration: > 4000 nM
Compound 4 was reported as a limit (the forecaster's own chance of this, stated with the estimate: 45%); the middle value sits exactly at the limit.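

Ethyl in place of methoxy on this aromatic carbon gives an at least 1.1-fold higher number from compound 1 to compound 4 (0.06 log units; that floor lies within the scatter), so only a floor for the change can be read, and the change could be small or large. Compound 4 gives a limit, not a number, and so the methoxy group of compound 1 cannot be ranked against ethyl. The series now clusters at a single ceiling: the limit of > 4000 nM in this assay, at which 3 of the 4 values shown sit.

The compounds shown leave open how an amine, a carboxylic acid or a chlorine atom at this position would read on the core of compound 1.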